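This account rests on a few compounds, and the source may have more. Where it says the series, first, only, none or still open, it means among the compounds named here.

Compound 1 `Cc1cccc(OCCCOc2ccc(-c3ccccc3CCC(=O)NS(=O)(=O)c3cccs3)cc2)c1`: 2900 nM; compound 2 `Cc1cccc(OCCCOc2ccc(-c3ccccc3CC(C)C(=O)NS(=O)(=O)c3cccs3)cc2)c1`: 2900 nM.

In an assay on isolated protein for binding affinity to prostaglandin E2 receptor EP2 subtype (Homo sapiens) (on this read-out higher numbers stand for weaker inhibition and lower numbers for stronger inhibition), compound 2 gives 2900 nM, level with compound 1 on the digits shown. The step from compound 2 to compound 3 `Cc1cccc(OCCCOc2ccc(-c3ccccc3CC(C)(C)C(=O)NS(=O)(=O)c3cccs3)cc2)c1` is methyl in place of hydrogen on a saturated chain carbon bound to a carbonyl carbon and two saturated chain carbons. Going by the values given here, the only measured step that bears on it is no change at the digits printed from compound 1 to compound 2 (within the scatter), a first methyl added on that same chain carbon with no shift beyond the scatter. On that single precedent, a second methyl there is expected to leave the affinity where it stands, giving an estimated no change at the digits printed from compound 2 to compound 3 (within the scatter). Compound 3 is therefore estimated at 2900 nM, within a range from 1000 nM to 8000 nM.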

Compound 3, inhibition constant: 2900 nM
Estimate against measurement, compound 3: no gap at the digits printed; measured number inside the range.
By their numbers in this assay, from the lowest: compounds 1, 2 and 3 (each within the scatter of the next).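

In this assay, a second methyl on this saturated chain carbon bound to a carbonyl carbon and two saturated chain carbons gives no change at the digits printed from compound 2 to compound 3 (within the scatter), so the flat result of the first methyl, no change at the digits printed from compound 1 to compound 2 (within the scatter), holds for a second one too. Nothing available explains why the reading stays flat.

Open, from the compounds shown here alone, is whether a larger or different group on this carbon, such as an ethyl, a hydroxyl or an amine, would shift the affinity. Also open, going by these compounds, is whether changing the thiophene sulfonyl end would do so.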